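Chain shortening and branching on the imidazole-side substituent

The compounds below may be only part of what the source reports. "The series", "measured", "known", "first", "only" and "open" are said of these compounds alone.

Of the compounds shown here, three on the shared core have been measured in a functional assay on ileum for inhibition of histamine H1 receptor (Cavia porcellus); a higher number here means a weaker inhibitor, a lower number a stronger inhibitor. Compound 1 `CCOCCn1c(N2CCN(C)CC2)nc2ccccc21` gives 10 nM; compound 2 `CCNCCn1c(N2CCN(C)CC2)nc2ccccc21` gives 290 nM; compound 3 `CCCCCCCn1c(N2CCN(C)CC2)nc2ccccc21` gives 150 nM. Compound 3 thus holds the second highest number of the three, with compound 2 as its nearest neighbour (a 1.9-fold lower number from compound 2 to compound 3 (0.29 log units; within the scatter)) and compound 1 as the furthest (a 15-fold higher number from compound 1 to compound 3 (1.18 log units; beyond the scatter)). The remaining step, a 29-fold higher number from compound 1 to compound 2 (1.46 log units; beyond the scatter), is likewise large.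

Compound 4 `CCCC(C)Cn1c(N2CCN(C)CC2)nc2ccccc21` differs from compound 3 by 1-methylbutyl in place of hexyl on a saturated chain carbon bound to an aromatic nitrogen; cut one bond further out, the same difference reads heptyl to 2-methylpentyl. Among the measured compounds shown here, none of the measured steps concerns a branched alkyl chain or a shortened one: all three replace ethoxy, ethylamino or pentyl at the same outer position, and the only purely alkyl-to-alkyl comparison, compound 2 to compound 3, stays within the scatter. The data therefore give no ground for expecting a change beyond the scatter in this assay, and the estimate for compound 4 is 150 nM (range 50 nM to 450 nM), a step of no change at the digits printed from compound 3 to compound 4 (within the scatter) that is expected to stay within the scatter.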

Compound 4, half-maximal inhibitory concentration: 500 nM
Beside the measured number, compound 4's estimate is 3.3-fold (0.52 log units) below it, and the stated range ends below it.
By their numbers in this assay, from the lowest: compound 1; then compounds 3, 2 and 4 (each within the scatter of the next, the first and the last beyond it).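

In this assay, among the compounds shown here, the change from hexyl to 1-methylbutyl on a saturated chain carbon bound to an aromatic nitrogen gives a 3.3-fold higher number from compound 3 to compound 4 (0.52 log units; beyond the scatter) and so shows that this position responds to a change between purely alkyl groups, which the earlier steps did not show. Among the other comparisons, a 1.7-fold higher number from compound 2 to compound 4 (0.24 log units; within the scatter) shows no separation, while a 50-fold higher number from compound 1 to compound 4 (1.70 log units; beyond the scatter) leaves compound 1, with its ethoxy-bearing chain, alone at the low end of the numbers. Nothing measured here bears on the origin of the step from hexyl to 1-methylbutyl.

This single pair does not separate the loss of one carbon from the branching, as the two change together. On these data alone, how a shorter straight chain such as butyl, or an ether chain carrying a methyl branch, would read at this position stays open.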